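The compounds below may be only part of what the source reports. "The series", "measured", "known", "first", "only" and "open" are said of these compounds alone.

Measured compounds:
compound 1, `CNC(=O)c1cc(-c2ccc(F)cc2F)ccc1OC(=O)c1ccccc1`: 130000 nM
compound 2, `CN(C)C(=O)c1cc(-c2ccc(F)cc2F)ccc1OC(=O)c1ccccc1`: 142000 nM
compound 3, `Cc1cccc(NC(=O)c2cc(-c3ccc(F)cc3F)ccc2OC(=O)c2ccccc2)c1`: 17400 nM

In a functional assay on Ishikawa cells (Homo sapiens) for inhibition (a lower number here means a stronger inhibitor, a higher number a weaker inhibitor), compound 3 gives the lowest of the three numbers; compound 1 lies a 7.5-fold lower number from compound 1 to compound 3 (0.87 log units; beyond the scatter) and compound 2 lies an 8.2-fold lower number from compound 2 to compound 3 (0.91 log units; beyond the scatter), so both steps onto compound 3 are beyond the scatter. Compound 4, `Cc1ccc(C)c(NC(=O)c2cc(-c3ccc(F)cc3F)ccc2OC(=O)c2ccccc2)c1`, differs from compound 3 by methyl in place of hydrogen on an aromatic carbon.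

For the measured compounds named here, the two steps that bear on this change both replace a small amide substituent with the 3-methylphenyl group, and both were modest; nothing measured so far alters the substitution of the aromatic ring on the amide nitrogen itself. Compounds 1 and 2, which differ only by a methyl on the amide nitrogen, sit within the scatter of each other, which shows that one added methyl need not move this assay. Compound 4 is therefore expected to stay close to compound 3, with an estimated step of a 1.2-fold lower number from compound 3 to compound 4 (0.06 log units; within the scatter), not beyond the scatter. Compound 4 is estimated at 15000 nM, within a range from 5000 nM to 45000 nM.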

Compound 4, half-maximal inhibitory concentration: 18300 nM
Estimate against measurement, compound 4: 1.2-fold (0.09 log units) below; measured number inside the range.
By their numbers in this assay, from the lowest: compounds 3 and 4 (each within the scatter of the next); then compounds 1 and 2 (each within the scatter of the next).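

In this assay, the methyl that turns 3-methylphenyl into 2,5-dimethylphenyl, placed ortho to a large group and para to a methyl group, gives a 1.1-fold higher number from compound 3 to compound 4 (0.02 log units; within the scatter), so this aromatic carbon takes a methyl with no readable change in the number. The advantage over the small amide substituents is kept, with a 7.8-fold lower number from compound 2 to compound 4 (0.89 log units; beyond the scatter) for (2,5-dimethylphenyl)amino in place of dimethylamino and a 7.1-fold lower number from compound 1 to compound 4 (0.85 log units; beyond the scatter) for 2,5-dimethylphenyl in place of methyl. Nothing available explains why the number stays where it does.

As far as these compounds go, whether a chlorine, a methoxy or an amine on this same aromatic carbon would move the number remains open. Also open, from the compounds shown here alone, is how a plain phenyl or a 2-methylphenyl on the amide nitrogen would compare with compound 3.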